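The compounds below may be only part of what the source reports. "The series", "measured", "known", "first", "only" and "open" are said of these compounds alone.

Compound 1, `CN(C)CCCCCCOc1ccc2oc(-c3ccccc3)cc(=O)c2c1`, and compound 2, `CCN(CC)CCCCCCOc1ccc2oc(-c3ccccc3)cc(=O)c2c1`, share a core and differ only in the amine at the end of the chain. In an assay on isolated protein (Cavia porcellus) with Sigma non-opioid intracellular receptor 1 (Homo sapiens) as the target, read by radioligand binding (on this read-out higher numbers stand for weaker inhibition and lower numbers for stronger inhibition), compound 1 gives 432 nM, while compound 2 gives 91 nM. Among the measured compounds shown here, the step of a 4.7-fold lower number from compound 1 to compound 2 (0.68 log units; beyond the scatter) is the only measured step in the set, and it leaves compound 2 standing at the lower of the two numbers.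

Compound 3, `CCOC(=O)C1CCN(CCCCCCOc2ccc3oc(-c4ccccc4)cc(=O)c3c2)CC1`, carries the change (4-(ethoxycarbonyl)piperidin-1-yl in place of diethylamino on a saturated chain carbon, six bonds along the chain from an oxygen on an aromatic ring). For the measured compounds named here, no measured pair shows this particular exchange, so the only guide is the step from compound 1 to compound 2, where enlarging the amine coincided with a lower number of modest size. Compound 3 enlarges the amine again but in a different way, and the set gives no direct reading on such a ring or on the ester it carries.

On that basis the expected step of a 1.2-fold higher number from compound 2 to compound 3 (0.08 log units; within the scatter) is small and uncertain in direction. Compound 3 is accordingly estimated at 110 nM in this assay, with a plausible range from 25 nM to 450 nM.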

Compound 3, half-maximal inhibitory concentration: 164 nM
Compound 3: middle estimate off by 1.5-fold (0.17 log units), on the low side; low and high end bracket the measured number.
By their numbers in this assay, from the lowest: compounds 2 and 3 (each within the scatter of the next); then compound 1.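

In this assay the exchange of diethylamino for 4-(ethoxycarbonyl)piperidin-1-yl, on a saturated chain carbon six bonds along the chain from an oxygen on an aromatic ring, gives a 1.8-fold higher number from compound 2 to compound 3 (0.26 log units; within the scatter) and so leaves compounds 2 and 3 indistinguishable on this read-out, although the entering group brings a six-membered non-aromatic ring and more heavy atoms. Set against the dimethylamino of compound 1, the same group gives a 2.6-fold lower number from compound 1 to compound 3 (0.42 log units; beyond the scatter) and thereby shows that the gap opened by the first step is not confined to diethylamino, since an amine of quite a different shape, with an ester on its ring, stands apart from dimethylamino in the same direction. No independent information is available on why the numbers fall as they do.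

The compounds shown do not separate the ring from the ester, so an unsubstituted piperidine or the corresponding carboxylic acid on the piperidine could show which of the two parts matters at this position. Going by these compounds, whether a morpholine would stay with compounds 2 and 3, and how any of these amines would behave on a shorter or longer chain, also remains open.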